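Bis-chalcone analogues in an HEK293 cytotoxicity assay

A few compounds are considered here, and "the series" means these few. Any claim that something is new, unique, unknown or untested is made for them only; others in the source may bear on it.

Measured compounds:
compound 1 `Cc1cc(O)c(C(=O)/C=C/c2ccccc2Cl)c(-c2ccccc2)c1C(=O)/C=C/c1ccccc1Cl`: "not active" (no number reported)
compound 2 `Cc1cc(O)c(C(=O)/C=C/c2ccc(OCc3ccccc3)cc2)c(-c2ccccc2)c1C(=O)/C=C/c1ccc(OCc2ccccc2)cc1`: 30000 nM
compound 3 `Cc1cc(O)c(C(=O)/C=C/c2ccc(Cl)cc2)c(-c2ccc(OCc3ccccc3)cc2)c1C(=O)/C=C/c1ccc(Cl)cc1`: "not active" (no number reported)

Of the compounds shown here, three sharing one core have been tested in an ADME assay on HEK293 cells (Homo sapiens) for cytotoxicity, read by MTT assay, with a stated time of 24 h; a lower number here means a stronger inhibitor, a higher number a weaker inhibitor. Compound 1 `Cc1cc(O)c(C(=O)/C=C/c2ccccc2Cl)c(-c2ccccc2)c1C(=O)/C=C/c1ccccc1Cl` is reported as "not active" (no number reported), and compound 3 `Cc1cc(O)c(C(=O)/C=C/c2ccc(Cl)cc2)c(-c2ccc(OCc3ccccc3)cc2)c1C(=O)/C=C/c1ccc(Cl)cc1` likewise as "not active" (no number reported); neither entry carries a number. Within the data shown here, compound 2 `Cc1cc(O)c(C(=O)/C=C/c2ccc(OCc3ccccc3)cc2)c(-c2ccccc2)c1C(=O)/C=C/c1ccc(OCc2ccccc2)cc1` is the only compound with a numerical result, giving 30000 nM in this assay, so it stands as the single point of reference, with no measured step available around it.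

Compound 4 `Cc1cc(O)c(C(=O)/C=C/c2ccc(OCc3ccccc3)cc2)c(-c2ccc(OCc3ccccc3)cc2)c1C(=O)/C=C/c1ccc(OCc2ccccc2)cc1` has not yet been tested. It differs from compound 2 in one place: benzyloxy in place of hydrogen on an aromatic carbon. Among the measured compounds shown here, no step between measured compounds covers a change of this kind. Given that compound 2 already sits at 30000 nM, and that its two companions report no number at all, the step from compound 2 to compound 4 is expected to be small, a 1.2-fold higher number from compound 2 to compound 4 (0.07 log units; within the scatter), or none beyond the scatter. Compound 4 is therefore estimated at 35000 nM in this assay, within a range from 12000 nM to 100000 nM.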

Compound 4, half-maximal inhibitory concentration: 30000 nM
Compound 4: the middle estimate sits 1.2-fold (0.07 log units) above what was measured, within the range that was stated.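

In this assay, among these compounds, putting benzyloxy in place of hydrogen gives no change at the digits printed from compound 2 to compound 4 (within the scatter), the first step that can be read. Among the compounds shown here, it shows that this aromatic carbon, para to a large group, can carry a group with a further six-membered aromatic ring while the compound keeps a numerical result at the same printed value, something the earlier compounds, only one of which had a number, could not show. Nothing shown here bears on why the value holds.

As far as these compounds go, whether an amine, a carboxylic acid or a simple methoxy group at this place would give the same reading remains open. So does whether benzyloxy here would leave the number as it stands if the other groups on the shared core were different.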